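Dimethylamino for isopropylamino on the shared core

The source may hold more compounds than are shown below. What is called first, only, known or untested is meant among the compounds shown, and "the series" means these compounds.

Measured in a functional assay on L02 cells (Homo sapiens) for inhibition, read by Griess assay, with stated times of 1 h and 24 h; on this read-out higher numbers stand for weaker inhibition and lower numbers for stronger inhibition:
- Compound 1 `CCCc1nn(C)c2c(NC(C)C)nc(/C=C/c3nc(C)c(C)nc3C)nc12` gives 342000 nM
- Compound 2 `CC(C)Nc1nc(/C=C/c2ccccc2)nc2ccsc12` gives > 1000000 nM (a limit)

Compound 2 stands at a limit of this assay (> 1000000 nM) and not at a number. Compound 3 `CN(C)c1nc(/C=C/c2ccccc2)nc2ccsc12` differs from compound 2 by dimethylamino in place of isopropylamino on an aromatic carbon. Going by the values given here, no measured step sizes this change. In this assay no step beyond the usual scatter is expected, in either direction. The estimated step is an at least 1.1-fold lower number from compound 2 to compound 3 (0.04 log units; that floor lies within the scatter) (an expectation only). Compound 3 is estimated at 900000 nM (range 300000 nM to 2000000 nM).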

Compound 3, half-maximal inhibitory concentration: > 1000000 nM
Compound 3 was reported as a limit (the forecaster's own chance of this, stated with the estimate: 55%); at least 1.1-fold (0.04 log units) between middle value and limit.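

Compound 2 and compound 3 are both reported as limits, not numbers, so no step between them can be read: the limit of > 1000000 nM in this assay, at which 2 of the 3 values shown sit.

Going by these compounds, how far dimethylamino in place of isopropylamino on an aromatic carbon moves the read-out, if at all, stays open.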